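The compounds below may be only part of what the source reports. "The series", "measured", "known", "first", "only" and "open" are said of these compounds alone.

Measured so far:

- Compound 1 `COc1cccc(OC)c1C(=O)Nc1c[nH]nc1C(=O)NC1CC1`: in an ADME assay on MRC5 cells (Homo sapiens) for inhibition, with a stated time of 72 h (on this read-out higher numbers stand for an effect only at larger amounts of compound and lower numbers for an effect already at smaller amounts), compound 1 gives > 50000 nM, which is a limit of the assay and not a number.
- Compound 2 `CO[C@H]1CC[C@H](NC(=O)c2n[nH]cc2NC(=O)c2ccccc2)CC1`: compound 2 gives 800 nM.
- Compound 3 `CO[C@H]1CC[C@H](NC(=O)c2n[nH]cc2NC(=O)c2ccccc2F)CC1`: compound 3 gives 1000 nM.

Compound 1 therefore stands only at a limit, the same one described by the limit of > 50000 nM in this assay, at which 1 of the 3 values shown sits. No number is known for it, only that its effect did not appear within the range tested.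

The untested compound 4 `COc1cccc(OC)c1C(=O)Nc1c[nH]nc1C(=O)NC1CCC(C)CC1` differs from compound 1 in one place: 4-methylcyclohexyl in place of cyclopropyl on an amide-type nitrogen. Among the compounds with values here, the only measured step between two compounds that differ in one place is a 1.3-fold higher number from compound 2 to compound 3 (0.10 log units; within the scatter), which concerns a fluoro on an aromatic carbon, not the group on the amide-type nitrogen, so it does not bear directly on this change. Compounds 2 and 3 carry a six-membered ring on that nitrogen and give numbers, while compound 1 with cyclopropyl sits at the limit, but these compounds differ from compound 1 in other places too, so no direction can be read from them.

For compound 4 in this assay the expected value is 40000 nM, with a range from 8000 nM to 50000 nM. This estimate means a step of an at least 1.2-fold lower number from compound 1 to compound 4 (0.09 log units; that floor lies within the scatter), and the outcome most expected is again a limit rather than a number.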

Compound 4, half-maximal effective concentration: 45000 nM
For compound 4 the middle estimate is 1.1-fold (0.05 log units) below the measured one; low and high end bracket the measured number.
By their numbers in this assay, from the lowest: compounds 2 and 3 (each within the scatter of the next); then compound 4. At a limit, above all of these: compound 1.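

In this assay, the exchange of cyclopropyl for 4-methylcyclohexyl on the amide-type nitrogen is the first step shown at this position, and it comes out as an at least 1.1-fold lower number from compound 1 to compound 4 (0.04 log units; that floor lies within the scatter). Going by these compounds, compound 1 holds only a limit and not a number, so the true size of this step stays unknown: the limit of > 50000 nM in this assay, at which 1 of the 4 values shown sits. Compound 4 does give a number, 45000 nM, which shows that a carbon ring with 7 heavy atoms in place of 3 on this nitrogen yields a value inside the tested range, although the effect still appears only at large amounts of compound.

The compounds shown do not tell whether the ring size or the methyl group accounts for this step, and a plain cyclohexyl on this nitrogen is not among them. They also leave open what a ring carrying an amine or a carboxylic acid, or a longer open chain, would give at this place on the core of compound 1.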